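The source may report more compounds than this note shows. Statements on the series, on what has been measured and on what is new or still open speak of the compounds shown alone.

Measured so far:
- compound 1, `Cc1cc(Nc2cc(-c3ccccc3)[nH]n2)n2nc(SCc3cccc(Br)c3)nc2n1`: 5140 nM
- compound 2, `Cc1cc(Nc2cc(-c3ccc(Cl)cc3)[nH]n2)n2nc(SCc3ccc(Br)cc3)nc2n1`: 3620 nM
- compound 3, `Cc1cc(Nc2cc(-c3cccs3)[nH]n2)n2nc(SCc3ccc(Br)cc3)nc2n1`: 5370 nM

These three compounds share one core and differ only in the group attached to an aromatic carbon of the five-membered ring and in the position of the bromine on the benzyl group. In a functional assay on MCF7 cells (Homo sapiens) for inhibition, read by MTT assay, with a stated time of 72 h (a higher number here means a weaker inhibitor, a lower number a stronger inhibitor), compound 3 gives 5370 nM, the highest of the three numbers, although its distance to compound 1 and to compound 2 is within the scatter of the measurement.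

Compound 4, `Cc1cc(Nc2cc(-c3ccc(F)cc3)[nH]n2)n2nc(SCc3ccc(Br)cc3)nc2n1`, is the next compound. The change from compound 3 is 4-fluorophenyl in place of thiophen-2-yl on an aromatic carbon.

Going by the values given here, the one measured step that bears on this change is the reverse of the move from compound 2 to compound 3: a 1.5-fold higher number from compound 2 to compound 3 (0.17 log units; within the scatter). A six-membered aromatic ring with one halogen in place of the thiophene therefore gave no change beyond the scatter. Among the compounds with values here, compound 1, which carries a plain phenyl, also falls within the scatter of compound 3, though its benzyl group differs as well, so no single-point step is available for it.

The expectation for compound 4 is a number near that of compound 2 or slightly lower than that of compound 3, a step of a 1.3-fold lower number from compound 3 to compound 4 (0.13 log units; within the scatter) that is not expected to exceed the scatter. Compound 4 is estimated at 4000 nM, with a likely range from 2000 nM to 8000 nM.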

Compound 4, half-maximal inhibitory concentration: 4570 nM
Beside the measured number, compound 4's estimate is 1.1-fold (0.06 log units) below it, within the range that was stated.
By their numbers in this assay, from the lowest: compounds 2, 4, 1 and 3 (each within the scatter of the next).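

In this assay, putting 4-fluorophenyl in place of thiophen-2-yl on this aromatic carbon gives a 1.2-fold lower number from compound 3 to compound 4 (0.07 log units; within the scatter), so a five-membered ring with sulfur and a six-membered carbon ring bearing fluorine cannot be told apart here. Changing only the halogen on the phenyl ring, with fluoro in place of chloro, gives a 1.3-fold higher number from compound 2 to compound 4 (0.10 log units; within the scatter), so the identity of this halogen makes no readable difference either. With the benzyl group held the same, the 4-chlorophenyl, 4-fluorophenyl and thiophen-2-yl compounds are now linked by steps that all stay within the scatter, and nothing available explains this similarity.

On these data alone, every group compared at this position is an aromatic ring, so the effect of a non-aromatic group remains open. An amine, a carboxylic acid or a longer alkyl chain on this carbon could show whether the number can move beyond the scatter.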